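The source may hold more compounds than are shown below. What is called first, only, known or untested is meant among the compounds shown, and "the series" means these compounds.

Three compounds have been measured in an ADME assay on RAW264.7 cells (Mus musculus) for cytotoxicity, read by WST assay; a higher number here means that more compound is tolerated, a lower number that less compound is tolerated:

Compound 1, `CC(C)(C)OC(=O)N(Cc1ccco1)C(=O)c1ccc(Cn2sc3ccccc3c2=O)cc1`, gives > 100000 nM.
Compound 2, `O=C(NCc1ccco1)c1ccc(Cn2sc3ccccc3c2=O)cc1`, gives > 100000 nM.
Compound 3, `CC(C)(C)OC(=O)N(Cc1ccco1)C(=O)c1ccc(Cn2c(=O)c3ccccc3[s+]2[O-])cc1`, gives 87300 nM.

The value of compound 1 is a limit of the assay, not a number. The value of compound 2 is likewise only a limit. Compound 3 is the only one of the three with a number.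

Compound 2 differs from compound 1 by hydrogen in place of tert-butoxycarbonyl on an amide-type nitrogen. The step that the two limits leave unreadable from compound 1 to compound 2 cannot be read because of the limit of > 100000 nM in this assay, at which 2 of the 3 values shown sit.

Compound 3 differs from compound 1 at the core: a group of 11 heavy atoms (7 carbon, 1 nitrogen, 2 oxygen, 1 sulfur; one five-membered aromatic ring with 2 hetero atoms, one six-membered aromatic ring of carbon only) in place of a group of 10 heavy atoms (7 carbon, 1 nitrogen, 1 oxygen, 1 sulfur; one five-membered aromatic ring with 2 hetero atoms, one six-membered aromatic ring of carbon only), on a saturated chain carbon bound to an aromatic carbon. The step of an at least 1.1-fold lower number from compound 1 to compound 3 (0.05 log units; that floor lies within the scatter) is small, so the two cores behave alike as far as these two values tell.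

Compound 4, `O=C(NCc1ccco1)c1ccc(Cn2c(=O)c3ccccc3[s+]2[O-])cc1`, has not been measured. It differs from compound 3 by hydrogen in place of tert-butoxycarbonyl on an amide-type nitrogen. For the measured compounds named here, this is the same change as the one from compound 1 to compound 2, at the same place, now made on the core of compound 3. For compound 4 a small step, a 1.0-fold higher number from compound 3 to compound 4 (0.01 log units; within the scatter), is expected, which rests on the earlier step that the two limits leave unreadable from compound 1 to compound 2 being unreadable and on the number of compound 3 standing close to the limit of this assay. The estimate for compound 4 is 90000 nM, with a likely range from 40000 nM to 200000 nM, and a fair chance that only a limit is reported.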

Compound 4, concentration lethal to 50% of the cells: > 100000 nM
Compound 4: a limit, no number (the forecaster's own chance of this, stated with the estimate: 60%); middle value at least 1.1-fold (0.04 log units) from the limit.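

In this assay, for the compounds shown here, hydrogen in place of tert-butoxycarbonyl on an amide-type nitrogen gives an at least 1.1-fold higher number from compound 3 to compound 4 (0.05 log units; that floor lies within the scatter), so on this core the change brings no sign that less compound is tolerated. Compound 4 gives > 100000 nM, which is a limit of the assay and not a number. This does not show that the change has the same size on both cores, or any particular size at all: the step on the core of compound 1 cannot be read, and the step on the core of compound 3 is known only as a floor, because so many values stop at the same point: the limit of > 100000 nM in this assay, at which 3 of the 4 values shown sit.

The compounds shown leave open whether another group on the amide-type nitrogen, such as an acetyl group, an amine-bearing chain or a longer chain, would bring the number down on either core. Also open, going by these compounds, is how much of each compound would be tolerated beyond the limit, which only a number for compound 2 or compound 4 could begin to settle.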